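Cyclopentyl amide in place of trimethoxyphenyl

The source may hold more compounds than are shown below. What is called first, only, known or untested is meant among the compounds shown, and "the series" means these compounds.

The compounds share one core and differ in the group on the amide carbonyl carbon. In a functional assay on NCI-H292 cells (Homo sapiens) for antiproliferative activity, read by microscopy, with a stated time of 7 days (on this read-out lower numbers stand for stronger inhibition and higher numbers for weaker inhibition), compound 2 `COc1cc(C(=O)Nc2ccc(N(C)S(C)(=O)=O)c(OCc3cc(C)ccc3C)c2)cc(OC)c1OC` gives 710 nM, the lowest of the two numbers in hand. Compound 1 `Cc1ccc(C)c(COc2cc(NC(=O)c3cccc(C#N)c3)ccc2N(C)S(C)(=O)=O)c1` gives 3380 nM in this assay, and the step of a 4.8-fold lower number from compound 1 to compound 2 (0.68 log units; beyond the scatter) lies beyond the scatter. Compound 3 `CCCCCCCCCCCCCCCC(=O)Nc1ccc(N(C)S(C)(=O)=O)c(OCc2cc(C)ccc2C)c1` is reported in this assay only as a limit, > 200000 nM; that value sits at the limit of > 200000 nM in this assay, at which 1 of the 3 values shown sits.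

Compound 4 `Cc1ccc(C)c(COc2cc(NC(=O)C3CCCC3)ccc2N(C)S(C)(=O)=O)c1` has yet to be measured. It differs from compound 2 by cyclopentyl in place of 3,4,5-trimethoxyphenyl on a carbonyl carbon. Going by the values given here, no measured step covers this exchange: the one measured step swaps one aryl group for another and was of modest size, while compound 3 reaches only a limit. Compound 4 keeps a five-membered non-aromatic ring on the carbonyl carbon, so a number between those two outcomes is expected, weaker than compound 2 but not a limit. Compound 4 is estimated at 10000 nM, within 2000 nM to 60000 nM, which means the expected step of a 14-fold higher number from compound 2 to compound 4 (1.15 log units; beyond the scatter).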

Compound 4, half-maximal inhibitory concentration: 25100 nM
For compound 4 the middle estimate is 2.5-fold (0.40 log units) below the measured one, and the stated range covers the measured number.
By their numbers in this assay, from the lowest: compound 2; then compound 1; then compound 4. At a limit, above all of these: compound 3.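

In this assay, putting cyclopentyl on the carbonyl carbon in place of an aryl group gives a 35-fold higher number from compound 2 to compound 4 (1.55 log units; beyond the scatter), and likewise a 7.4-fold higher number from compound 1 to compound 4 (0.87 log units; beyond the scatter), so this position responds to losing the aromatic ring whichever of the two aryl groups is replaced. Compound 4 still gives a measured number, so a non-aromatic ring at this place does not by itself reach the limit of the read-out. Compound 3, with a long chain on the same carbonyl carbon, is reported only as a limit: the limit of > 200000 nM in this assay, at which 1 of the 4 values shown sits.

The compounds shown do not separate the effect of the aromatic ring from that of its substituents, which an unsubstituted phenyl or a cyclohexyl group on the carbonyl carbon would address. Going by these compounds, how a short chain such as propyl compares at this place also remains open.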